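Triazole series: moving to a trifluoromethylphenyl on the ring carbon

The source may report more compounds than this note shows. Statements on the series, on what has been measured and on what is new or still open speak of the compounds shown alone.

Compound 1 `Cc1cccc(-c2nc(CNc3ccc(C(=O)NO)cc3)n(-c3ccccc3)n2)c1` is one of three members measured in an assay on Sf9 cells for inhibition of protein deacetylase HDAC6 (Homo sapiens), read by fluorescence, with a stated time of 40 min, tested at 100 nM; a lower number here means less inhibition, a higher number more inhibition at the concentration tested (going by the name of the read-out). Compound 1 gives 64.1%, the second highest of the three numbers. Compound 2 `Cc1cccc(-n2nc(-c3ccccc3)nc2CNc2ccc(C(=O)NO)cc2)c1` is nearest, giving 66% in this assay, a difference within the scatter. Compound 3 `O=C(NO)c1ccc(NCc2nc(-c3ccccc3)nn2-c2ccc(Cl)cc2)cc1` is furthest, giving 55.4% in this assay, also within the scatter of compound 1.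

For the measured compounds named here, the only step between measured compounds is a number 10.6 percentage points lower from compound 2 to compound 3 (beyond the scatter), a change in the group on an aromatic nitrogen.

The next compound, compound 4 `O=C(NO)c1ccc(NCc2nc(-c3ccc(C(F)(F)F)cc3)nn2-c2ccccc2)cc1`, differs from compound 1 in one place: 4-(trifluoromethyl)phenyl in place of 3-methylphenyl on an aromatic carbon. Going by the values given here, no measured step changes this position, so the step from compound 2 to compound 3 is the only one that exchanges 3-methylphenyl for a para-type phenyl, though it sits on an aromatic nitrogen rather than on an aromatic carbon. Taken as a loose guide, it points to a modest loss, and a small drop in this assay, possibly within the scatter, is expected for compound 4, with the step of a number 7.1 percentage points lower from compound 1 to compound 4 (within the scatter) as the estimate. The expected value for compound 4 is 57%, in the range 45% to 68%.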

Compound 4, a percentage reported as inhibition, at one concentration (the size of the read-out at that concentration, not a potency): 41.6%
For compound 4 the middle estimate is 15.4 percentage points above the measured one; measured number outside the range, below it.
By their numbers in this assay, from the lowest: compound 4; then compounds 3, 1 and 2 (each within the scatter of the next, the first and the last beyond it).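

On the aromatic carbon between two ring nitrogen atoms, 4-(trifluoromethyl)phenyl in place of 3-methylphenyl gives in this assay a number 22.5 percentage points lower from compound 1 to compound 4 (beyond the scatter), the first step read at this position, so the aryl group held here does matter for the core of compound 1. The two groups count the same for hydrogen-bond donors, hydrogen-bond acceptors and net charge, and each holds one six-membered aromatic ring of carbon only; what differs is 10 heavy atoms against 7, the three fluorine atoms and the place of the substituent on the phenyl ring, all changed in one step. No measurement to hand accounts for the size of this step.

On these data alone, whether the loss goes with the trifluoromethyl group itself or with its place on the phenyl ring stays open, and 3-(trifluoromethyl)phenyl and 4-methylphenyl on this same carbon would pull the two apart. Also open, as far as these compounds go, is whether a 3-aminophenyl or a 3-methoxyphenyl at this position would stay level with compound 1 in this assay or fall as well.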